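The source may hold more compounds than are shown below. What is called first, only, known or untested is meant among the compounds shown, and "the series" means these compounds.

The measured compounds, with their numbers in a functional assay on PC-3 cells (Homo sapiens) for cytotoxicity, read by MTT assay, with a stated time of 72 h; a lower number here means a stronger inhibitor, a higher number a weaker inhibitor:
compound 1 `O=C(Nc1nc2ccc(Cl)cc2s1)c1cn(-c2ccccc2)nc1-c1ccccc1`, 3690 nM
compound 2 `O=C(Nc1nc2ccc(Cl)cc2s1)c1cn(-c2ccccc2)nc1-c1ccc(Cl)cc1`, 3230 nM
compound 3 `COc1ccc(-c2nn(-c3ccccc3)cc2C(=O)Nc2nc3ccc(F)cc3s2)cc1`, 4930 nM

In this assay compound 3 is set apart from compound 1 and from compound 2 only by gaps that fall within the scatter, so the three numbers cannot be told apart. For the measured compounds named here, the single step measured between two compounds that differ in one place, a 1.1-fold lower number from compound 1 to compound 2 (0.06 log units; within the scatter), concerns chloro in place of hydrogen on an aromatic carbon and also stays within the scatter.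

Compound 4 `COc1ccc(-c2nn(-c3ccccc3)cc2C(=O)Nc2nc3ccc(Cl)cc3s2)cc1` differs from compound 3 by chloro in place of fluoro on an aromatic carbon, read one bond further out as 6-fluoro-1,3-benzothiazol-2-yl becoming 6-chloro-1,3-benzothiazol-2-yl. Going by the values given here, no measured step covers a fluoro-to-chloro exchange at this place. Compound 1 and compound 2 already carry the chloro-bearing fused ring, and their numbers lie within the scatter of compound 3, which gives no sign that this exchange shifts the read-out. The expected step, a 1.4-fold lower number from compound 3 to compound 4 (0.14 log units; within the scatter), is therefore small, with no direction that should reach beyond the scatter. Compound 4 is estimated at 3600 nM, with a range from 1500 nM to 8500 nM.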

Compound 4, half-maximal inhibitory concentration: 6510 nM
Beside the measured number, compound 4's estimate is 1.8-fold (0.26 log units) below it; low and high end bracket the measured number.
By their numbers in this assay, from the lowest: compounds 2, 1, 3 and 4 (each within the scatter of the next).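

In this assay, for the compounds shown here, the change from 6-fluoro-1,3-benzothiazol-2-yl to 6-chloro-1,3-benzothiazol-2-yl gives a 1.3-fold higher number from compound 3 to compound 4 (0.12 log units; within the scatter) and so provides the first direct reading of a halogen exchange at this place on the fused ring: with the methoxy group held constant, the two halogens cannot be told apart. Compound 4 also links this series to the two earlier chloro compounds, since a methoxy group put where the one carries hydrogen gives a 1.8-fold higher number from compound 1 to compound 4 (0.25 log units; within the scatter) and a methoxy group put where the other carries chloro gives a 2.0-fold higher number from compound 2 to compound 4 (0.30 log units; within the scatter). Neither of these changes moves the number beyond the scatter, so all three steps show only that these substituents make no measurable difference here.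

On these data alone, it remains open whether the exchange of fluoro for chloro would read the same with hydrogen or chloro in place of the methoxy group. As far as these compounds go, it is also open whether a group of another kind at this place on the fused ring, such as an amine or a carboxylic acid, would shift the number beyond the scatter. No evidence is available that would explain any of these readings.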